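From Sulfamide to Methanesulfonamide on a Shared Core

The compounds below may be only part of what the source reports. "The series", "measured", "known", "first", "only" and "open" are said of these compounds alone.

Compound 1 `NS(=O)(=O)NCCSc1nonc1/C(=N/O)Nc1ccc(F)c(Br)c1`: 2.8 nM
Compound 2 `N#CCC(=O)NCCSc1nonc1/C(=N/O)Nc1ccc(F)c(C(F)F)c1`: 6.5 nM

In an assay for inhibition of Indoleamine 2,3-dioxygenase 1 (Homo sapiens), read by fluorescence, with a stated time of 24 h (on this read-out higher numbers stand for weaker inhibition and lower numbers for stronger inhibition), compound 1 gives the lowest number of the two, and compound 2 gives a higher one, beyond the usual scatter. Compound 3 `CS(=O)(=O)NCCSc1nonc1/C(=N/O)Nc1ccc(F)c(Br)c1` differs from compound 1 in one place: methyl in place of amino on a sulfonyl sulfur. Going by the values given here, no measured pair shows this change, so its size is not known from these compounds. A modest move toward a higher number, a 2.5-fold higher number from compound 1 to compound 3 (0.40 log units; beyond the scatter), is expected in this assay. Compound 3 is expected to give 7 nM in this assay, within 2.5 nM to 20 nM.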

Compound 3, half-maximal inhibitory concentration: 9.3 nM
The estimate for compound 3 lay 1.3-fold (0.12 log units) below the measured number; low and high end bracket the measured number.
By their numbers in this assay, from the lowest: compound 1; then compounds 2 and 3 (each within the scatter of the next).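

In this assay, methyl in place of amino on the sulfonyl sulfur gives a 3.3-fold higher number from compound 1 to compound 3 (0.52 log units; beyond the scatter), so this position responds to the change, though the step is modest. Inhibition does not depend entirely on the amino group, since compound 3 still gives 9.3 nM. No available evidence explains the size of this step.

The compounds shown leave open how an ethyl or a dimethylamino group on the same sulfonyl sulfur would read. They also leave open whether this step would keep its size with difluoromethyl in place of bromine on the shared core.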